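The compounds below may be only part of what the source reports. "The series", "measured", "known", "first", "only" and "open" are said of these compounds alone.

Measured compounds:
- compound 1, `CC(=O)Nc1cccc2c(-c3cccc(NC(=O)c4ccc(Cl)c(C(F)(F)F)c4)c3)ccnc12`: 2400 nM
- compound 2, `CC(=O)Nc1cccc2c(-c3cccc(NC(=O)c4ccc(C(F)(F)F)c(Cl)c4)c3)ccnc12`: 7600 nM

Among the measured compounds shown here, in a functional assay on A375P cells (Homo sapiens) for antiproliferative activity, read by MTT assay, with a stated time of 48 h (a higher number here means a weaker inhibitor, a lower number a stronger inhibitor), compound 2 gives 7600 nM, the higher of the two numbers; its one neighbour is compound 1, and the step of a 3.2-fold higher number from compound 1 to compound 2 (0.50 log units; beyond the scatter) lies beyond the scatter. Compound 3, `CC(=O)Nc1cccc2c(-c3cccc(NC(=O)c4ccc(F)c(C(F)(F)F)c4)c3)ccnc12`, is not yet measured. Its change from compound 2 is 4-fluoro-3-(trifluoromethyl)phenyl in place of 3-chloro-4-(trifluoromethyl)phenyl on a carbonyl carbon. For the measured compounds named here, only the step from compound 1 to compound 2 bears on this, and it was modest. Compound 3 carries the 4-fluoro-3-(trifluoromethyl)phenyl group, which has its trifluoromethyl placed as in the 4-chloro-3-(trifluoromethyl)phenyl group of compound 1, with fluorine rather than chlorine as the other substituent. Compound 3 is therefore expected to land near compound 1, giving an estimated 3000 nM within 1200 nM to 7500 nM, an expected step of a 2.5-fold lower number from compound 2 to compound 3 (0.40 log units; beyond the scatter) in this assay.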

Compound 3, half-maximal inhibitory concentration: 6800 nM
For compound 3 the middle estimate is 2.3-fold (0.36 log units) below the measured one; the measured number falls inside the stated range.
By their numbers in this assay, from the lowest: compound 1; then compounds 3 and 2 (each within the scatter of the next).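

In this assay, fluoro in place of chloro on an aromatic carbon gives a 2.8-fold higher number from compound 1 to compound 3 (0.45 log units; beyond the scatter) and so shows that the trifluoromethyl placement shared by compound 1 and compound 3 does not by itself keep the lower number. The exchange of 3-chloro-4-(trifluoromethyl)phenyl for 4-fluoro-3-(trifluoromethyl)phenyl gives a 1.1-fold lower number from compound 2 to compound 3 (0.05 log units; within the scatter) and leaves the two compounds together, so compound 1, with both chlorine and that trifluoromethyl placement, stands apart from both. Nothing available explains this difference between chloro and fluoro.

The compounds shown leave open whether bromo, methyl or a nitrile in place of the chloro of compound 1 would keep its number. They also leave open whether replacing the acetamide of the shared core with an amine or a longer chain would alter these steps.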